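Fluoro to methoxy on the benzothiazole: a second instance

The source may report more compounds than this note shows. Statements on the series, on what has been measured and on what is new or still open speak of the compounds shown alone.

Measured compounds:
compound 1 `Cc1ccc(-c2ccc(C)n2-c2ccc(-c3nc4ccc(F)cc4s3)cc2)cc1` gives 2150 nM
compound 2 `COc1cc(-c2ccc(C)n2-c2ccc(-c3nc4ccc(F)cc4s3)cc2)cc(OC)c1OC` gives 1410 nM
compound 3 `COc1ccc2nc(-c3ccc(-n4c(C)ccc4-c4ccc(C)cc4)cc3)sc2c1` gives 2570 nM

All three were tested in a functional assay on MCF7 cells (Homo sapiens) for cytotoxicity, read by sulforhodamine B assay, with a stated time of 48 h; a lower number here means a stronger inhibitor of growth, a higher number a weaker inhibitor of growth. Compound 2 has the lowest number of the three, but its gap to compound 1 and to compound 3 lies within the scatter, so no order among them is claimed. The difference between the core of compound 1 and the core of compound 2 is not broken down here.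

From compound 1 to compound 3 the change is methoxy in place of fluoro on an aromatic carbon, and the step was a 1.2-fold higher number from compound 1 to compound 3 (0.08 log units; within the scatter). Compound 4 `COc1ccc2nc(-c3ccc(-n4c(C)ccc4-c4cc(OC)c(OC)c(OC)c4)cc3)sc2c1` carries the same change against compound 2: methoxy in place of fluoro on an aromatic carbon. Because the measured step of a 1.2-fold higher number from compound 1 to compound 3 (0.08 log units; within the scatter) lay within the scatter, the step from compound 2 to compound 4 is expected to be similarly small, a 1.2-fold higher number from compound 2 to compound 4 (0.08 log units; within the scatter). Compound 4 is therefore estimated at 1700 nM in this assay, with a range from 800 nM to 3600 nM.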

Compound 4, concentration for 50% growth inhibition: 920 nM
Compound 4: the middle estimate sits 1.8-fold (0.27 log units) above what was measured, within the range that was stated.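

In this assay the change from 6-fluoro-1,3-benzothiazol-2-yl to 6-methoxy-1,3-benzothiazol-2-yl gave a 1.5-fold lower number from compound 2 to compound 4 (0.19 log units; within the scatter), so on this second core the step is again small. This shows that the change carries from one core to the other without a difference that can be told from scatter, and the opposite directions of the two steps are not to be read as a real reversal. It rests on two pairs and does not show how the change would behave on any other core, so no general rule follows: the same change on two cores in this assay, a 1.2-fold higher number (0.08 log units; within the scatter) from compound 1 to compound 3 and a 1.5-fold lower number (0.19 log units; within the scatter) from compound 2 to compound 4, 1.8-fold (0.26 log units) apart, within the scatter of two such steps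

The compounds shown leave open whether a different group on that same aromatic carbon, such as an amine or a carboxylic acid, would give a step beyond the scatter.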